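Diarylamine to biaryl swap in the diene series

The compounds below may be only part of what the source reports. "The series", "measured", "known", "first", "only" and "open" are said of these compounds alone.

Measured compounds:
compound 1, `C=C[C@@](C)(/C=C/c1ccc(Nc2ccc(F)cc2)cc1)CCC=C(C)C`, > 43400 nM
compound 2, `C=C[C@@](C)(/C=C/c1ccc(Nc2cc(F)c(F)c(F)c2)cc1)CCC=C(C)C`, > 43400 nM

The read-out throughout is a functional assay on NALM-6 cells (Homo sapiens) for cytotoxicity, with a stated time of 72 h; a lower number here means that less compound is needed, a higher number that more compound is needed for the effect. Compound 1 gives only a limit of the assay, > 43400 nM, and not a number. Compound 2 likewise gives only a limit, > 43400 nM. The step that the two limits leave unreadable from compound 1 to compound 2 therefore cannot be read. All that can be said is summarised in the limit of > 43400 nM in this assay, at which 2 of the 2 values shown sit: neither compound reaches a measurable effect.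

Compound 3, `C=C[C@@](C)(/C=C/c1ccc(-c2ccc(Cl)c(Cl)c2)cc1)CCC=C(C)C`, has not yet been measured. It differs from compound 1 by 3,4-dichlorophenyl in place of (4-fluorophenyl)amino on an aromatic carbon. Among the measured compounds shown here, no measured step bears on this change; the only step on record is unreadable, and it alters a different part of the molecule. The shared core and the diene-bearing chain are unchanged.

With both measured compounds at the limit, the expectation for compound 3 is a value near or beyond that limit, and the step of a number no higher from compound 1 to compound 3 (the limit leaves the size open) is expected to stay within the scatter. Compound 3 is estimated at 43400 nM in this assay, with a range from 10000 nM to 150000 nM, most likely reported again only as a limit.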

Compound 3, half-maximal effective concentration: > 43400 nM
Compound 3 gave a limit, no number; the forecaster's own chance of this, stated with the estimate: 70%; the middle value sits exactly at the limit.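

In this assay compound 3 gives only a limit, > 43400 nM, and not a number. No step between compound 1 and compound 3 can be read, and the series offers no comparison: the limit of > 43400 nM in this assay, at which 3 of the 3 values shown sit.

Open remains whether 3,4-dichlorophenyl and (4-fluorophenyl)amino differ at all in this assay, and which changes to the shared core would bring a measurable value.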